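A Thiophene Ring Replaces the Chlorophenyl Group

The compounds below may be only part of what the source reports. "The series", "measured", "known", "first", "only" and "open" are said of these compounds alone.

Compound 1 `Fc1ccc(C2(c3ccc(F)cc3)CNC(c3cccc(Cl)c3)=N2)cc1` is the reference point of this small set. In an assay on LM cells for displacement of a labelled ligand from Neuropeptide Y receptor type 5 (Homo sapiens) (on this read-out higher numbers stand for weaker inhibition and lower numbers for stronger inhibition), compound 1 gives 5.4 nM, the lowest number among the three measured compounds. Compound 2 `CC(=O)c1cccc(C2=NC(c3ccc(F)cc3)(c3ccc(F)cc3)CN2)c1` gives 44 nM in this assay, and compound 3 `Nc1cccc(C2=NC(c3ccc(F)cc3)(c3ccc(F)cc3)CN2)c1` gives 300 nM. The measured steps all concern the group on an aromatic carbon: an 8.1-fold higher number from compound 1 to compound 2 (0.91 log units; beyond the scatter), a 56-fold higher number from compound 1 to compound 3 (1.74 log units; beyond the scatter) and a 6.8-fold higher number from compound 2 to compound 3 (0.83 log units; beyond the scatter). Every change away from chloro raised the number.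

Compound 4 `Fc1ccc(C2(c3ccc(F)cc3)CNC(c3cccs3)=N2)cc1` is not yet measured. It differs from compound 1 in a single place: thiophen-2-yl in place of 3-chlorophenyl on a carbon with a double bond to nitrogen. The exchange removes the six-membered aromatic ring of carbon only together with its chlorine and brings in a five-membered aromatic ring with one hetero atom and one hydrogen-bond acceptor. For the measured compounds named here, none of the measured steps alters the ring itself; they vary only the group on an aromatic carbon, so they bear on this change indirectly at most. Still, because an 8.1-fold higher number from compound 1 to compound 2 (0.91 log units; beyond the scatter) and a 56-fold higher number from compound 1 to compound 3 (1.74 log units; beyond the scatter) both point upward, the chloro of compound 1 appears hard to improve upon, and its loss is expected to carry a price. The step of a 3.7-fold higher number from compound 1 to compound 4 (0.57 log units; beyond the scatter) is therefore expected to be modest and toward a higher number. Compound 4 is estimated at 20 nM, with a range from 5 nM to 80 nM.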

Compound 4, half-maximal inhibitory concentration: 54 nM
For compound 4 the middle estimate is 2.7-fold (0.43 log units) below the measured one, and the stated range covers the measured number.
By their numbers in this assay, from the lowest: compound 1; then compounds 2 and 4 (each within the scatter of the next); then compound 3.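

Exchanging the whole aromatic ring at this position, and not only the group it carries, gives a 10-fold higher number from compound 1 to compound 4 (1.00 log units; beyond the scatter) in this assay and shows that thiophen-2-yl does not match the 3-chlorophenyl of compound 1 here. The same ring still compares well with the other substituted phenyl groups: in place of 3-aminophenyl it gives a 5.6-fold lower number from compound 3 to compound 4 (0.74 log units; beyond the scatter) and in place of 3-acetylphenyl it gives a 1.2-fold higher number from compound 2 to compound 4 (0.09 log units; within the scatter) and thus, on this carbon with a double bond to nitrogen, a change of the ring itself and a change of the group on the phenyl ring can reach the same level. Nothing in the data shown accounts for these differences.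

The compounds shown leave open how much of the step away from compound 1 belongs to the loss of the chlorine and how much to the change of ring, a question that an unsubstituted phenyl ring or a chlorine carried on the thiophen-2-yl ring would address. They also leave open how a thiophen-3-yl, furan-2-yl or pyridinyl ring would stand at this carbon.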